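From carboxymethyl to 2-carboxyethyl: working notes on the series

The source may report more compounds than this note shows. Statements on the series, on what has been measured and on what is new or still open speak of the compounds shown alone.

Values in a functional assay on MCF7 cells (Homo sapiens) for antiproliferative activity, read by MTT assay, with a stated time of 72 h (on this read-out higher numbers stand for weaker inhibition and lower numbers for stronger inhibition), so far
Compound 1 `CCn1c(C(=O)On2nnc3ccccc32)ccc1C(CC)(CC)c1ccc(C#CC(O)(CC)CC)c(C)c1` gives > 50000 nM (a limit)
Compound 2 `CCn1c(C(=O)NCC(=O)O)ccc1C(CC)(CC)c1ccc(C#CC(O)(CC)CC)c(C)c1` gives 5140 nM
Compound 3 `CCn1c(C(=O)NCCC(=O)O)ccc1C(CC)(CC)c1ccc(C#CC(O)(CC)CC)c(C)c1` is not yet measured

Among the measured compounds shown here, compound 2 gives 5140 nM and holds the only actual number. The value of compound 1 is a limit and not a number.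

The change carboxymethyl in place of carboxy on a saturated chain carbon bound to an amide-type nitrogen turns the (carboxymethyl)carbamoyl of compound 2 into the (2-carboxyethyl)carbamoyl of compound 3, with carboxymethyl in place of carboxy on a saturated chain carbon bound to an amide-type nitrogen. The rest of the structure stays the same.

For the measured compounds named here, the only measured step is an at least 9.7-fold lower number from compound 1 to compound 2 (0.98 log units; beyond the scatter) and it exchanges a much larger group on a carbonyl carbon. That step rests on the limit of > 50000 nM in this assay, at which 1 of the 2 values shown sits, and offers little guidance for so small a change. In this assay no step beyond the scatter is therefore expected, and neither direction is favoured. Going by the values given here, the expectation is anchored on compound 2 at 5140 nM as the sole number available. The estimated step is a 1.1-fold higher number from compound 2 to compound 3 (0.03 log units; within the scatter) and it is expected to remain small. Compound 3 is estimated at 5500 nM with 2000 nM to 16000 nM as the expected range.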

Compound 3, half-maximal inhibitory concentration: > 50000 nM
Compound 3: only a limit was reported; the forecaster's own chance of this, stated with the estimate: 10%; middle value at least 9.0-fold (0.95 log units) from the limit.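

In this assay compound 3 gives > 50000 nM, which is a limit and not a number. On a saturated chain carbon bound to an amide-type nitrogen, carboxymethyl in place of carboxy gives an at least 9.7-fold higher number from compound 2 to compound 3 (0.98 log units; beyond the scatter), so this position responds strongly to a change far smaller than the exchange on the carbonyl carbon seen earlier, and among the carbamoyl groups shown only the (carboxymethyl)carbamoyl of compound 2 returns an actual number. How large the step really is stays unread, and the series now rests mostly on one limit: the limit of > 50000 nM in this assay, at which 2 of the 3 values shown sit.

The step between compound 1 and compound 3 cannot be read, since it joins two limits. Still open, from the compounds shown here alone, is whether the loss follows the longer chain or the place of the carboxylic acid on it, a question that a methyl ester or a primary amide in place of carboxy on the carboxymethyl of compound 2, or a 3-carboxypropyl on the same amide-type nitrogen, would bear on.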